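The compounds below may be only part of what the source reports. "The series", "measured", "known", "first", "only" and "open" are said of these compounds alone.

Measured so far in an assay on Ltk cells with metabotropic glutamate receptor 5 (Homo sapiens) as the target, read by fluorescence and calcium flux; a higher number here means a weaker inhibitor, a lower number a stronger inhibitor:
- compound 1 `CCOc1cc(C#N)cnc1Nc1cccc(C)n1` — 46 nM
- compound 2 `CCOc1cc(-c2ccsn2)cnc1Nc1cccc(C)n1` — 243 nM

Among the measured compounds shown here, compound 2 stands at the weaker end of these two numbers: the one step measured, a 5.3-fold higher number from compound 1 to compound 2 (0.72 log units; beyond the scatter), lies beyond the scatter and separates it clearly from compound 1.

The next compound, compound 3 `CCOc1cc(Oc2cccnc2)cnc1Nc1cccc(C)n1`, is not yet measured. Its change from compound 2 is (pyridin-3-yl)oxy in place of 1,2-thiazol-3-yl on an aromatic carbon. For the measured compounds named here, the single measured step, a 5.3-fold higher number from compound 1 to compound 2 (0.72 log units; beyond the scatter), bears on it only indirectly: it shows what happened when the cyano group of compound 1 was replaced by the five-membered ring of compound 2, not what a second aromatic ring linked through oxygen does at the same carbon. Going by the values given here, no measured pair exchanges one ring for another at that position, so the direction of the step to compound 3 cannot be read from the data. The working expectation is that compound 3 stays close to compound 2, with a broad range on either side; the expected step is a 1.2-fold higher number from compound 2 to compound 3 (0.09 log units; within the scatter). For compound 3 the estimate in this assay is 300 nM, expected to fall between 80 nM and 1200 nM.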

Compound 3, half-maximal inhibitory concentration: 18 nM
For compound 3 the middle estimate is 17-fold (1.22 log units) above the measured one; measured number below the stated range.
By their numbers in this assay, from the lowest: compound 3; then compound 1; then compound 2.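

At this carbon, meta to the ethoxy group and para to the group of 8 heavy atoms, the choice of ring-bearing substituent has a large effect in this assay: the step of a 14-fold lower number from compound 2 to compound 3 (1.13 log units; beyond the scatter) shows that the loss seen with the 1,2-thiazol-3-yl group does not apply to every aromatic ring placed here. The (pyridin-3-yl)oxy group also surpasses the nitrile, with a 2.6-fold lower number from compound 1 to compound 3 (0.41 log units; beyond the scatter), so replacing the nitrile with a ring-bearing group can move the number in either direction, and compound 3 is the strongest inhibitor of the three. No available evidence accounts for the difference between these groups.

The change to compound 3 alters the ring size, the ring hetero atoms and the oxygen link together, so the compounds shown leave open which of these carries the step; a phenoxy group, a directly attached pyridin-3-yl group or a (pyridin-3-yl)methyl group at the same carbon would separate them. Also open, on these data alone, is how the position responds to an amine or a carboxylic acid, and whether the pyridine nitrogen in the (pyridin-3-yl)oxy group matters at all.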